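Swapping the Halogenated Aryl Ring on a Stable Core

The source may report more compounds than this note shows. Statements on the series, on what has been measured and on what is new or still open speak of the compounds shown alone.

Compound 1 `Clc1ccc(-c2nc(NCCNc3ccccn3)ncc2-c2ncc[nH]2)c(Cl)c1` was tested in an ADME assay on microsomes from liver (Rattus norvegicus) for metabolic stability (a lower number here means that the compound disappears faster, a higher number that the compound lasts longer), and gave > 0.5 h, which is a limit of the assay rather than a number. Compound 2 `Nc1nc(NCCNc2ncc(-c3ncc[nH]3)c(-c3ccccc3Cl)n2)ccc1[N+](=O)[O-]` gave > 0.5 h, again a limit. Compound 3 `Nc1nc(NCCNc2ncc(-c3ncc[nH]3)c(-c3ccc(F)cc3Cl)n2)ccc1[N+](=O)[O-]` gave > 0.5 h, also a limit. Among the measured compounds shown here, the only measured step that touches this ring is a step that the two limits leave unreadable from compound 2 to compound 3, so it cannot guide a size. Compound 4 `Cc1ccc(-c2nc(NCCNc3ccc([N+](=O)[O-])c(N)n3)ncc2-c2ncc[nH]2)c(Br)c1` differs from compound 3 in one place: 2-bromo-4-methylphenyl in place of 2-chloro-4-fluorophenyl on an aromatic carbon. Because (the limit of > 0.5 h in this assay, at which 3 of the 3 values shown sit), no reading in this assay has yet fallen below the limit, and no shift beyond the usual scatter is expected here. Compound 4 is expected to give about 1 h, within the range 0.4 h to 3 h. The expected step is a step that the limit leaves unreadable from compound 3 to compound 4, most likely again reported only as a limit.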

Compound 4, half-life: > 0.5 h
Compound 4 was reported as a limit (the forecaster's own chance of this, stated with the estimate: 80%); the middle value does not contradict the limit.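

No step can be read between compound 2, compound 3 and compound 4, because all three sit at the same limit: the limit of > 0.5 h in this assay, at which 4 of the 4 values shown sit. As far as these compounds go, how far each half-life lies past that limit, and whether the group swapped on the shared core changes it, stays open.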